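The compounds below may be only part of what the source reports. "The series", "measured", "known", "first", "only" and "open" are said of these compounds alone.

Three compounds share one core and differ only in the group carried on a saturated chain carbon bound to an aromatic carbon. In an in vitro functional assay on cells for agonist activity at Bombesin receptor subtype-3 (Homo sapiens), read by luminescence and calcium flux (on this read-out lower numbers stand for an effect already at smaller amounts and higher numbers for an effect only at larger amounts of compound), compound 1 `O=C(O)c1ccccc1-c1ccc(CCc2ncc(CC3CCOCC3)[nH]2)cc1` gives 338 nM, compound 2 `N#Cc1ccc(Cc2cnc(CCc3ccc(-c4ccccc4C(=O)O)cc3)[nH]2)cc1` gives 5890 nM, and compound 3 `O=C(O)c1ccccc1-c1ccc(CCc2ncc(Cc3ccc(Cl)cc3)[nH]2)cc1` gives 2290 nM. Compound 3 thus stands second highest of the three: the step of a 2.6-fold lower number from compound 2 to compound 3 (0.41 log units; beyond the scatter) is modest, the step of a 6.8-fold higher number from compound 1 to compound 3 (0.83 log units; beyond the scatter) is larger, and the step of a 17-fold higher number from compound 1 to compound 2 (1.24 log units; beyond the scatter) is the largest seen. Compound 4 `CC(C)(C)CCc1cnc(CCc2ccc(-c3ccccc3C(=O)O)cc2)[nH]1` carries the change (neopentyl in place of 4-chlorophenyl on a saturated chain carbon bound to an aromatic carbon). Within the data shown here, no measured pair covers exactly this exchange; what the data show is that both groups with an aromatic ring, in compound 2 and compound 3, give higher numbers than the oxan-4-yl of compound 1, and that neopentyl, like oxan-4-yl, carries no aromatic ring. The step expected into compound 4 is therefore downward, a 2.5-fold lower number from compound 3 to compound 4 (0.41 log units; beyond the scatter), though the size is uncertain. The estimate for compound 4 in this assay is 900 nM, within 250 nM to 3200 nM.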

Compound 4, half-maximal effective concentration: 39 nM
For compound 4 the middle estimate is 23-fold (1.36 log units) above the measured one; the whole stated range lies above it.
By their numbers in this assay, from the lowest: compound 4; then compound 1; then compound 3; then compound 2.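

In this assay, among these compounds, the place on a saturated chain carbon bound to an aromatic carbon proves far more sensitive than the earlier compounds showed, since the changes to neopentyl (a 59-fold lower number from compound 3 to compound 4 (1.77 log units; beyond the scatter) and a 150-fold lower number from compound 2 to compound 4 (2.18 log units; beyond the scatter)) are both larger than any earlier step. Neopentyl, with carbon only and no ring, also gives a lower number than oxan-4-yl (an 8.7-fold lower number from compound 1 to compound 4 (0.94 log units; beyond the scatter)), so a low number here requires neither a ring nor the oxygen of oxan-4-yl. Across these four compounds, the two groups without an aromatic ring give the lower numbers, with no compound going against this, but no available evidence explains the order.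

As far as these compounds go, whether a longer carbon chain, a cyclohexyl ring or an amine at this place would lower the number further remains open. The compounds shown also leave open how far the neopentyl result depends on the rest of the shared core.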